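The source may report more compounds than this note shows. Statements on the series, on what has been measured and on what is new or still open speak of the compounds shown alone.

Compound 1 `Cc1ccsc1C(=O)OC(CCN(C)C)c1ccc(Cl)cc1`: 119%
Compound 2 `Cc1ccc(C(=O)NC(CCN(C)C)c2ccc(Cl)cc2)c(C)c1`: 147%

In an assay on NIH3T3 cells with Urotensin-2 receptor (Homo sapiens) as the target (on this read-out higher numbers stand for larger maximal responses and lower numbers for smaller maximal responses), compound 1 gives 119%, the lower of the two values shown, and compound 2 gives 147%, a gap beyond the usual scatter. Compound 3 `Cc1ccccc1NC(=O)OC(CCN(C)C)c1ccc(Cl)cc1` is not yet measured. It differs from compound 1 in one place: (2-methylphenyl)amino in place of 3-methylthiophen-2-yl on a carbonyl carbon. For the measured compounds named here, no measured pair shows this change, so the direction rests only on the two values above. The step from compound 1 to compound 3 is expected to be modest and upward, a number 11 percentage points higher from compound 1 to compound 3 (beyond the scatter). Compound 3 is therefore estimated to reach 130%, with a range from 100% to 160%.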

Compound 3, largest response reached (reported as efficacy), in percent of the reference or control that the assay uses: 176%
For compound 3 the middle estimate is 46 percentage points below the measured one, and the stated range ends below it.
By their numbers in this assay, from the lowest: compound 1; then compound 2; then compound 3.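

In this assay, putting (2-methylphenyl)amino in place of 3-methylthiophen-2-yl on a carbonyl carbon gives a number 57 percentage points higher from compound 1 to compound 3 (beyond the scatter) and so shows that this position can carry a large change in maximal response. The swap exchanges a five-membered aromatic ring with 1 hetero atom for a six-membered aromatic ring of carbon only and also brings in a hydrogen-bond donor, so this one step cannot separate these features. Nothing shown here accounts for the rise.

As far as these compounds go, it remains open whether a phenylamino group without the methyl, or a cyclohexylamino group, on the same carbonyl carbon would give a similar response.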